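Removing the bromoethenyl carbonyl group from compound 1

This account rests on a few compounds, and the source may have more. Where it says the series, first, only, none or still open, it means among the compounds named here.

compound 1 `C=C(Br)C(=O)Nc1ccc(/C=C/C(=O)c2ccc(OC)cc2)cc1`: 1400 nM
compound 2 `C=C(Br)C(=O)Nc1ccc(/C=C/C(=O)c2cccc(OC)c2)cc1`: 700 nM

In a functional assay on HeLa cells (Homo sapiens) for antiproliferative activity, with a stated time of 48 h (a higher number here means a weaker inhibitor, a lower number a stronger inhibitor), compound 1 gives 1400 nM. It has a single measured neighbour, and the comparison reads a 2.0-fold lower number from compound 1 to compound 2 (0.30 log units; within the scatter), so the two cannot be told apart. The next compound, compound 3 `COc1ccc(C(=O)/C=C/c2ccc(N)cc2)cc1`, has not yet been measured. It differs from compound 1 as follows: hydrogen in place of (1-bromoethenyl)carbonyl on a nitrogen on an aromatic ring. Put simply, hydrogen takes the place of (1-bromoethenyl)carbonyl on a nitrogen on an aromatic ring, so ((1-bromoethenyl)carbonyl)amino becomes amino.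

Going by the values given here, the one measured step offers little guidance. It only swaps 4-methoxyphenyl for 3-methoxyphenyl and leaves this nitrogen untouched, so it gives no size for the new change. Among the compounds with values here, no measured compound lacks the group. The expectation is therefore a judgement, starting from compound 1 at 1400 nM: losing so large a piece should give a clearly higher number, meaning a weaker inhibitor, well beyond the scatter. The expected step is an 11-fold higher number from compound 1 to compound 3 (1.03 log units; beyond the scatter). For compound 3 the estimated value is 15000 nM, with an expected range from 4000 nM to 50000 nM.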

Compound 3, half-maximal inhibitory concentration: 98000 nM
Estimate against measurement, compound 3: 6.5-fold (0.82 log units) below; measured number above the stated range.
By their numbers in this assay, from the lowest: compounds 2 and 1 (each within the scatter of the next); then compound 3.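

Taking the (1-bromoethenyl)carbonyl off the nitrogen on the aromatic ring gives, in this assay, a 70-fold higher number from compound 1 to compound 3 (1.85 log units; beyond the scatter), so activity in these cells depends strongly on what sits at this position. This is the first change among these compounds that moves the number beyond the scatter, since swapping 4-methoxyphenyl for 3-methoxyphenyl did not. No measurement at hand accounts for the size of this loss.

As far as these compounds go, the change removes the carbonyl, the bromine and the carbon-carbon double bond all at once, so it remains open which of these parts matters, and an acetyl group or a (1-chloroethenyl)carbonyl on the same nitrogen would help to pull them apart. Also open, from the compounds shown here alone, is whether the same loss would appear with 3-methoxyphenyl in place of 4-methoxyphenyl, as in compound 2, where the amino form would be the matching comparison.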